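Cytotoxicity of Compound 3 and a Cycloheptyl Replacement

The compounds below may be only part of what the source reports. "The series", "measured", "known", "first", "only" and "open" are said of these compounds alone.

Measured compounds:
Compound 1 `Cc1ccc(NC(=O)C(=O)NC(c2nc(C)c(CCO)s2)C2CCCCN2)c(F)c1`: in an ADME assay on TZM-b1 cells (Homo sapiens) for cytotoxicity, read by XTT assay, with a stated time of 3 days (on this read-out lower numbers stand for higher toxicity in this test and higher numbers for lower toxicity in this test), compound 1 gives > 78800 nM, which is a limit of the test.
Compound 2 `Cc1nc(C(NC(=O)C(=O)Nc2ccc(F)cc2)C2CCCCN2)sc1CO`: compound 2 gives > 90000 nM, also a limit.
Compound 3 `Cc1nc(C(NC(=O)C(=O)Nc2ccc(F)cc2)C2CCCCN2)sc1CCO`: compound 3 gives > 88000 nM, also a limit.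

Because every value is a limit, the step that the two limits leave unreadable from compound 1 to compound 3 and the step that the two limits leave unreadable from compound 2 to compound 3 cannot be sized; compound 3 stands at a limit alongside two further limits the limit of > 88000 nM in this assay, at which 1 of the 3 values shown sits, the limit of > 90000 nM in this assay, at which 1 of the 3 values shown sits (the limit of > 78800 nM in this assay, at which 1 of the 3 values shown sits). Compound 4 `Cc1nc(C(NC(=O)C(=O)NC2CCCCCC2)C2CCCCN2)sc1CCO` differs from compound 3 by cycloheptyl in place of 4-fluorophenyl on an amide-type nitrogen. Going by the values given here, no measured step bears on this change, so nothing in the data points to a difference in this assay beyond the usual scatter. For compound 4 a step that the limit leaves unreadable from compound 3 to compound 4 is expected, and its estimated value is 90000 nM, within 40000 nM to 200000 nM.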

Compound 4, half-maximal cytotoxic concentration: > 88000 nM
Compound 4 ended at the assay's limit (the forecaster's own chance of this, stated with the estimate: 85%); the middle value is on the limit's open side.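

Compound 1, compound 3 and compound 4 all end at limits of this assay, and the steps between them cannot be read. The compounds shown leave open whether cycloheptyl and 4-fluorophenyl differ in toxicity at all.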